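Removing the chloro from compound 2: an expected dead end

The source may report more compounds than this note shows. Statements on the series, on what has been measured and on what is new or still open speak of the compounds shown alone.

Compound 1 `COc1ccc(/C=N/n2c(SCc3ccc(F)cc3)nnc2-c2cc(OC)c(OC)c(OC)c2)c(OC)c1` and compound 2 `COc1ccc(/C=N/n2c(SCc3ccccc3Cl)nnc2-c2cc(OC)c(OC)c(OC)c2)c(OC)c1` share one core and differ only in the group on a saturated chain carbon bound to a sulfur. In a functional assay on HepG2 cells (Homo sapiens) for cytotoxicity, read by MTT assay, with a stated time of 48 h (a higher number here means a weaker inhibitor, a lower number a stronger inhibitor), compound 1 gives only a limit of the assay, > 200000 nM. In this assay compound 2 likewise gives only a limit, > 200000 nM. Within the data shown here, the one measured step, a step that the two limits leave unreadable from compound 1 to compound 2, is unreadable. Compound 2 thus stands where every measured value sits, at the limit of > 200000 nM in this assay, at which 2 of the 2 values shown sit. Compound 3 `COc1ccc(/C=N/n2c(SCc3ccccc3)nnc2-c2cc(OC)c(OC)c(OC)c2)c(OC)c1` arises from compound 2 by hydrogen in place of chloro on an aromatic carbon. No readable measured step bears on this change, and no direction beyond the scatter can be drawn from it. Compound 3 is expected to stay at the limit, the step that the limit leaves unreadable from compound 2 to compound 3 being an expectation only. For compound 3 the estimated value in this assay is 300000 nM, within 150000 nM to 1000000 nM.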

Compound 3, half-maximal inhibitory concentration: 60900 nM
Compound 3: middle estimate off by 4.9-fold (0.69 log units), on the high side; the measured number lies below the stated range.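

In this assay, compound 3 alone among the three gives a number rather than a limit, so the benzylsulfanyl compound is the only one that can be placed on the scale. Both readable steps run the same way, an at least 3.2-fold lower number from compound 2 to compound 3 (0.51 log units; beyond the scatter) and an at least 3.2-fold lower number from compound 1 to compound 3 (0.51 log units; beyond the scatter), so hydrogen on this ring gives a lower number than either halogen shown, and since both steps start from a limit, their true size remains unknown. The step between the two halogen compounds cannot be read, as both remain at a limit of the assay: the limit of > 200000 nM in this assay, at which 2 of the 3 values shown sit.

As far as these compounds go, whether chloro and fluoro differ at all stays open. From the compounds shown here alone, it is also open whether another group on this ring, such as an amine or a hydroxyl, or a longer chain to the sulfur, would lower the number further.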